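Removing the chloro of compound 2: an expected limit

The source may report more compounds than this note shows. Statements on the series, on what has been measured and on what is new or still open speak of the compounds shown alone.

Compound 1 `COc1cccc(/C=C/C(=O)c2sc(Nc3ccc(Cl)cc3)nc2C)c1`, compound 2 `Cc1nc(Nc2cccc(Cl)c2)sc1C(=O)/C=C/c1ccccc1` and compound 3 `Cc1nc(Nc2cccc(Cl)c2)sc1C(=O)/C=C/c1ccc(Cl)cc1` share one core and were all examined in a functional assay on NCI-H460 cells (Homo sapiens) for cytotoxicity, read by MTT assay; on this read-out higher numbers stand for weaker inhibition and lower numbers for stronger inhibition. Compound 1 gives only a limit there, > 25000 nM. Compound 2 likewise gives only a limit, > 25000 nM. Compound 3 also gives only a limit, > 25000 nM. So compound 2 stands where every measured compound stands, namely at the limit of > 25000 nM in this assay, at which 3 of the 3 values shown sit. For the measured compounds named here, the one step that can be drawn among them, a step that the two limits leave unreadable from compound 2 to compound 3, has no readable size because the limit of > 25000 nM in this assay, at which 3 of the 3 values shown sit, holds both of its ends.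

Compound 4 `Cc1nc(Nc2ccccc2)sc1C(=O)/C=C/c1ccccc1` has not yet been measured in this assay. It differs from compound 2 by hydrogen in place of chloro on an aromatic carbon. Going by the values given here, no measured step bears on this change with a readable size; the closest comparison, a step that the two limits leave unreadable from compound 2 to compound 3, concerns a chloro at the same kind of position and stays unreadable. Compound 4 is therefore expected to remain at the limit of this assay as well, with an estimate of 40000 nM and a range from 15000 nM to 150000 nM. The step from compound 2 to compound 4 is expected to be a step that the limit leaves unreadable from compound 2 to compound 4, none beyond the scatter.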

Compound 4, half-maximal inhibitory concentration: > 25000 nM
Compound 4 ended at the assay's limit; the forecaster's own chance of this, stated with the estimate: 80%; the middle value is on the limit's open side.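

Compound 4 ends at a limit in this assay, as compound 2 does, so no step between compound 2 and compound 4 can be read: the limit of > 25000 nM in this assay, at which 4 of the 4 values shown sit.

The compounds shown leave open whether any change on the shared core would give a value that is not a limit in this assay.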